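The source may hold more compounds than are shown below. What is called first, only, known or untested is meant among the compounds shown, and "the series" means these compounds.

Working notes on the series; all numbers come from an assay on CHO cells for displacement of a labelled ligand from D(4) dopamine receptor (Homo sapiens), read by radioligand binding; on this read-out higher numbers stand for weaker inhibition and lower numbers for stronger inhibition.

Compound 1, `COc1ccccc1N1CCN(CCCNC(=O)NN(Cc2ccc(F)cc2)c2ccc(F)cc2)CC1`, gives 4.6 nM.
Compound 2, `COc1cccc(CN(NC(=O)NCCCN2CCN(c3ccccc3OC)CC2)c2ccc(F)cc2)c1`, gives 5.9 nM.
Compound 3, `COc1ccc(N(Cc2ccc(F)cc2)NC(=O)NCCCN2CCN(c3ccccc3OC)CC2)cc1`, gives 2.9 nM.

Compound 4, `COc1ccc(N(Cc2cccc(OC)c2)NC(=O)NCCCN2CCN(c3ccccc3OC)CC2)cc1`, has not yet been measured in this assay. It differs from compound 3 by 3-methoxyphenyl in place of 4-fluorophenyl on a saturated chain carbon bound to a nitrogen on an aromatic ring. The same change is already on record once, from compound 1 to compound 2, where it gave a 1.3-fold higher number from compound 1 to compound 2 (0.11 log units; within the scatter). The two cores on which the change is made differ by methoxy in place of fluoro on an aromatic carbon; that core change itself gave a 1.6-fold lower number from compound 1 to compound 3 (0.20 log units; within the scatter). The place of the benzyl change is described in the same words for both pairs, so the change on compound 3 is taken as the same change as on compound 1.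

Because the earlier step of a 1.3-fold higher number from compound 1 to compound 2 (0.11 log units; within the scatter) was within the scatter, the expected step from compound 3 to compound 4 is of similar size, a 1.3-fold higher number from compound 3 to compound 4 (0.12 log units; within the scatter). The expectation rests on one prior pair only and is correspondingly uncertain. Compound 4 is therefore expected to give 3.8 nM, with the likely range running from 1.8 nM to 8 nM.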

Compound 4, inhibition constant: 33 nM
Compound 4: the middle estimate sits 8.7-fold (0.94 log units) below what was measured, outside the stated range (above it).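

In this assay, the change from 4-fluorobenzyl to 3-methoxybenzyl does not carry over from the core of compound 1 to the core of compound 3, where it gives an 11-fold higher number from compound 3 to compound 4 (1.06 log units; beyond the scatter), and the two readings of this change differ: the same change on two cores in this assay, a 1.3-fold higher number (0.11 log units; within the scatter) from compound 1 to compound 2 and an 11-fold higher number (1.06 log units; beyond the scatter) from compound 3 to compound 4, 8.9-fold (0.95 log units) apart, beyond the scatter of two such steps

The methoxy in place of fluoro on an aromatic carbon likewise reads differently once the 3-methoxybenzyl group is present, giving a 5.6-fold higher number from compound 2 to compound 4 (0.75 log units; beyond the scatter), and this too stands apart from its earlier reading: the same change on two cores in this assay, a 1.6-fold lower number (0.20 log units; within the scatter) from compound 1 to compound 3 and a 5.6-fold higher number (0.75 log units; beyond the scatter) from compound 2 to compound 4, 8.9-fold (0.95 log units) apart, beyond the scatter of two such steps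

The two changes are therefore not additive across these four compounds, and a step read on one core does not predict the step on the other here, but this single set shows neither the cause nor whether the same holds on any other core.

Still open, on these data alone, is whether the jump needs the 3-methoxybenzyl group itself or would also appear with a plain benzyl or a chlorobenzyl group. Also open, as far as these compounds go, is whether an amine or a nitrile in place of the methoxy on the aromatic carbon would behave as the methoxy does or as the fluoro does.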